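Cytotoxicity Limits Across Three Nitroimidazole Ethers and a Fourth

This account rests on a few compounds, and the source may have more. Where it says the series, first, only, none or still open, it means among the compounds named here.

Three compounds were run in an ADME assay on MRC5 cells (Homo sapiens) for cytotoxicity, read by resazurin assay, with a stated time of 72 h; on this read-out lower numbers stand for stronger inhibition and higher numbers for weaker inhibition. Compound 1 `CC1(COc2ccc(-c3ccc(F)nc3F)nc2)CCn2cc([N+](=O)[O-])nc2O1` reaches only a limit of the assay, > 64000 nM. Compound 2 `CC1(COc2ccc(-c3ccc(F)cc3F)nc2)CCn2cc([N+](=O)[O-])nc2O1` likewise reaches only a limit, > 64000 nM. Compound 3 `CC1(COc2ccc(-c3ccc(F)cc3F)cn2)CCn2cc([N+](=O)[O-])nc2O1` also stops at a limit, > 64000 nM. The change from compound 2 to compound 1 is 2,6-difluoropyridin-3-yl in place of 2,4-difluorophenyl on an aromatic carbon, and the step that the two limits leave unreadable from compound 2 to compound 1 cannot be sized because of the limit of > 64000 nM in this assay, at which 3 of the 3 values shown sit. Compound 2 and compound 3 are built from the same atoms joined differently; the difference between the two cores is not broken down here.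

Compound 4 `CC1(COc2ccc(-c3ccc(F)nc3F)cn2)CCn2cc([N+](=O)[O-])nc2O1` has not yet been measured. It differs from compound 3 by 2,6-difluoropyridin-3-yl in place of 2,4-difluorophenyl on an aromatic carbon, the same kind of change as that between compound 2 and compound 1, though here the entering group stands two atoms from the ring nitrogen rather than next to the ring nitrogen. Because every measured value sits at the limit of > 64000 nM in this assay, at which 3 of the 3 values shown sit, compound 4 is expected to move by no more than a number no higher from compound 3 to compound 4 (the limit leaves the size open). In this assay compound 4 is therefore estimated at 64000 nM, most probably again only a limit.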

Compound 4, half-maximal inhibitory concentration: > 64000 nM
Compound 4 ended at the assay's limit (the forecaster's own chance of this, stated with the estimate: 85%); the middle value sits exactly at the limit.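

No step can be read from compound 3 to compound 4 in this assay, because both compounds stop at a limit and give no number: the limit of > 64000 nM in this assay, at which 4 of the 4 values shown sit. The compounds shown leave open whether 2,6-difluoropyridin-3-yl in place of 2,4-difluorophenyl, or the difference between the two cores, changes cytotoxicity at all.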